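The source may report more compounds than this note shows. Statements on the series, on what has been measured and on what is new or still open speak of the compounds shown alone.

Working notes on the series. In a functional assay on A549 cells (Homo sapiens) for inhibition, read by MTT assay, with a stated time of 48 h (on this read-out higher numbers stand for weaker inhibition of growth and lower numbers for stronger inhibition of growth), compound 1 `Cn1cc(C2CC(c3ccccc3)=NN2C(=O)c2ccc(Cl)nc2)c2ccccc21` gives 8460 nM. Compound 2 `Cn1cc(C2CC(c3ccccc3)=NN2C(=O)c2cccnc2Cl)c2ccccc21` reads > 10000 nM, which is a limit of the assay and not a number. Compound 2 therefore has no position beyond that limit: the limit of > 10000 nM in this assay, at which 1 of the 2 values shown sits.

Next is compound 3 `Cn1cc(C2CC(c3ccccc3)=NN2C(=O)c2ccncc2)c2ccccc21`, with the change (pyridin-4-yl in place of 2-chloropyridin-3-yl on a carbonyl carbon). Among the measured compounds shown here, only one measured step bears on it, and it also alters the acyl group on that carbonyl carbon: an at least 1.1-fold higher number from compound 1 to compound 2 (0.07 log units; that floor lies within the scatter). For the measured compounds named here, no measured step isolates the loss of the chlorine, so the change has no direct precedent. Going by the values given here, with only that small step as a guide, no change beyond the scatter is expected in this assay, and no direction is favoured.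

The expected step is an at least 1.1-fold lower number from compound 2 to compound 3 (0.04 log units; that floor lies within the scatter). For compound 3 the estimated value is 9000 nM, with an expected range from 4000 nM to 20000 nM.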

Compound 3, concentration for 50% growth inhibition: 990 nM
Estimate against measurement, compound 3: 9.1-fold (0.96 log units) above; the measured number lies below the stated range.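

Unlike the step between the two chloropyridines, the acyl group on the carbonyl carbon now moves the read-out beyond the scatter in this assay, with pyridin-4-yl giving (an 8.5-fold lower number from compound 1 to compound 3 (0.93 log units; beyond the scatter)) and (an at least 10-fold lower number from compound 2 to compound 3 (1.00 log units; beyond the scatter)). Both changes remove the chlorine and alter the ring's attachment together, so the gain cannot be assigned to either alone. The second step is only a floor, since compound 2 sits at a limit of the assay: the limit of > 10000 nM in this assay, at which 1 of the 3 values shown sits.

Going by these compounds, whether the gain follows the loss of the chlorine or the pyridin-4-yl ring itself stays open, and an unsubstituted pyridin-3-yl would separate the two. On these data alone, how far the acyl group tolerates other rings, such as a plain phenyl or a pyridin-4-yl carrying an amine, also remains unknown.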